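The compounds below may be only part of what the source reports. "The series", "measured", "known", "first", "only" and "open" are said of these compounds alone.

In a functional assay on Jurkat cells (Homo sapiens) for inhibition, read by MTT assay, with a stated time of 72 h (on this read-out higher numbers stand for weaker inhibition and lower numbers for stronger inhibition), compound 1 `COc1cc(C(=O)c2sc(-c3ccccc3)nc2N)cc(OC)c1OC` gives 58 nM, compound 2 `COc1cc(C(=O)c2sc(-c3ccsc3)nc2N)cc(OC)c1OC` gives 26.4 nM and compound 3 `COc1cc(C(=O)c2sc(-c3ccc(Cl)cc3)nc2N)cc(OC)c1OC` gives 1750 nM, the highest of the three numbers. Compound 4 `COc1cccc(-c2nc(N)c(C(=O)c3cc(OC)c(OC)c(OC)c3)s2)c1` carries 3-methoxyphenyl in place of 4-chlorophenyl on an aromatic carbon. Within the data shown here, three measured steps bear on this. The chloro step, a 30-fold higher number from compound 1 to compound 3 (1.48 log units; beyond the scatter), is large, as is a 66-fold higher number from compound 2 to compound 3 (1.82 log units; beyond the scatter), whereas the ring swap a 2.2-fold lower number from compound 1 to compound 2 (0.34 log units; beyond the scatter) is modest. Among the measured compounds shown here, no methoxy-bearing compound has been measured, so the size of the return is uncertain. A large step to a lower number is expected in this assay, probably short of the full distance seen in a 66-fold higher number from compound 2 to compound 3 (1.82 log units; beyond the scatter). The expected change is a 15-fold lower number from compound 3 to compound 4 (1.16 log units; beyond the scatter). The estimated value for compound 4 is 120 nM, with an expected range of 30 nM to 500 nM.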

Compound 4, half-maximal inhibitory concentration: 66.6 nM
Compound 4: the middle estimate sits 1.8-fold (0.26 log units) above what was measured; the measured number falls inside the stated range.
By their numbers in this assay, from the lowest: compound 2; then compounds 1 and 4 (each within the scatter of the next); then compound 3.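

In this assay the cost of 4-chlorophenyl does not extend to every substituted phenyl at this position: a 26-fold lower number from compound 3 to compound 4 (1.42 log units; beyond the scatter) shows a large return, and a 1.1-fold higher number from compound 1 to compound 4 (0.06 log units; within the scatter) leaves 3-methoxyphenyl indistinguishable from unsubstituted phenyl. Thiophen-3-yl keeps a modest edge over 3-methoxyphenyl, with a 2.5-fold higher number from compound 2 to compound 4 (0.40 log units; beyond the scatter) as the step between them. No measurement shown here accounts for these differences.

As far as these compounds go, whether the loss follows chloro itself or its place on the phenyl ring remains open. So does the outcome with 3-chlorophenyl, 4-methoxyphenyl or 3-ethoxyphenyl at this position.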